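The compounds below may be only part of what the source reports. "The series", "measured", "known", "first", "only" and "open" are said of these compounds alone.

Measured compounds:
- compound 1, `O=C(O)c1ccccc1-c1ccc(CCc2ncc(Cc3cccc(F)c3)[nH]2)cc1`: 159 nM
- compound 2, `CCCCc1cnc(C(CC)Cc2ccc(-c3ccccc3C(=O)O)cc2)[nH]1`: 2720 nM
- compound 3, `CCCCc1cnc(C(CCCO)Cc2ccc(-c3ccccc3C(=O)O)cc2)[nH]1`: 1900 nM

In an in vitro functional assay on cells for agonist activity at Bombesin receptor subtype-3 (Homo sapiens), read by luminescence and calcium flux (a lower number here means that less compound is needed, a higher number that more compound is needed for the effect), compound 1 gives 159 nM, the lowest of the three numbers. Compound 3 gives 1900 nM and compound 2 gives 2720 nM; both stand above compound 1 by more than the scatter, and the two carry a different substituent pattern on the shared core, so neither gap is a single-point step. Going by the values given here, the only single-point step measured is the one between those two: a 1.4-fold lower number from compound 2 to compound 3 (0.16 log units; within the scatter).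

Compound 4, `O=C(O)c1ccccc1-c1ccc(CCc2ncc(Cc3cccc(Cl)c3)[nH]2)cc1`, differs from compound 1 as follows: chloro in place of fluoro on an aromatic carbon.

Among the compounds with values here, no measured step exchanges one halogen for another on the benzyl ring, so nothing speaks directly to this change. Within the data shown here, the one step that is known, a 1.4-fold lower number from compound 2 to compound 3 (0.16 log units; within the scatter), concerns a chain position elsewhere on the core and was within the scatter; it offers no direction for the halogen exchange. On that basis a step of no more than the scatter is expected in this assay, with no preferred direction.

Compound 4 is therefore estimated at 140 nM, with a range of 55 nM to 400 nM. The expected step is a 1.1-fold lower number from compound 1 to compound 4 (0.06 log units; within the scatter).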

Compound 4, half-maximal effective concentration: 825 nM
For compound 4 the middle estimate is 5.9-fold (0.77 log units) below the measured one; measured number outside the range, above it.
By their numbers in this assay, from the lowest: compound 1; then compound 4; then compounds 3 and 2 (each within the scatter of the next).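

In this assay, going by these compounds alone, the halogen on the benzyl ring proves not to be an interchangeable detail: chloro in place of fluoro gives a 5.2-fold higher number from compound 1 to compound 4 (0.72 log units; beyond the scatter), the first single-point change to exceed the scatter. Within the data shown here, the only earlier single-point comparison, a 1.4-fold lower number from compound 2 to compound 3 (0.16 log units; within the scatter), lay at a saturated chain carbon and stayed within the scatter, so it gave no sign that the series could respond this clearly to a change of one heavy atom. On the shared core of compound 1 and compound 4, this aromatic position is therefore sensitive to the identity of the substituent, with the 3-fluorobenzyl group giving the lower number of the pair, but no measurement at hand accounts for the size or direction of this step.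

Still open, going by these compounds, is how hydrogen, bromo, methyl, methoxy or trifluoromethyl at this same place would compare with fluoro and chloro, which would show whether the two halogens belong to a wider trend. Also open, on these data alone, is whether the step from fluoro to chloro keeps its size and direction when the halogen stands on another carbon of the ring, or when an amide or a tetrazole takes the place of the carboxylic acid.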